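A few compounds are considered here, and "the series" means these few. Any claim that something is new, unique, unknown or untested is made for them only; others in the source may bear on it.

Compound 3 `CCOC(=O)C(C)(C)Oc1ccc2c(=O)cc(-c3cc(C(C)(C)C)c(O)c(C(C)(C)C)c3)oc2c1` gives 500 nM in a functional assay on cells (Endothelial cell) for inhibition (a lower number here means a stronger inhibitor, a higher number a weaker inhibitor), the lowest of the three numbers in hand. Compound 1 `CC(C)(C)c1cc(-c2cc(=O)c3ccc(O)cc3o2)cc(C(C)(C)C)c1O` gives 2000 nM, and compound 2 `CC(C)(C)c1cc(-c2cc(=O)c3ccccc3o2)cc(C(C)(C)C)c1O` gives 2500 nM. Compound 4 `CCOC(=O)COc1ccc2c(=O)cc(-c3cc(C(C)(C)C)c(O)c(C(C)(C)C)c3)oc2c1` differs from compound 3 in one place: (ethoxycarbonyl)methyl in place of 1-(ethoxycarbonyl)-1-methylethyl on an oxygen on an aromatic ring. The steps that touch this side of the molecule are a 4.0-fold lower number from compound 1 to compound 3 (0.60 log units; beyond the scatter) and a 5.0-fold lower number from compound 2 to compound 3 (0.70 log units; beyond the scatter), both modest gains from building out the chain on the ring oxygen. For the measured compounds named here, no measured pair varies the chain itself, so the effect of the shortened chain is not tested here. The author therefore expects compound 4 to stay close to compound 3, with a step of a 1.4-fold higher number from compound 3 to compound 4 (0.15 log units; within the scatter) estimated to sit within the scatter, and expects for compound 4 a value of 700 nM, in the range 300 nM to 1600 nM.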

Compound 4, half-maximal inhibitory concentration: 800 nM
Compound 4: the middle estimate sits 1.1-fold (0.06 log units) below what was measured, and the stated range covers the measured number.
By their numbers in this assay, from the lowest: compounds 3 and 4 (each within the scatter of the next); then compounds 1 and 2 (each within the scatter of the next).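

Trading 1-(ethoxycarbonyl)-1-methylethyl for (ethoxycarbonyl)methyl on the oxygen gives a 1.6-fold higher number from compound 3 to compound 4 (0.20 log units; within the scatter) in this assay and still leaves a 3.1-fold lower number from compound 2 to compound 4 (0.49 log units; beyond the scatter) and a 2.5-fold lower number from compound 1 to compound 4 (0.40 log units; beyond the scatter) as gains for the shorter chain. The gain over the compounds without a chain therefore does not require the larger of the two chains. Nothing at hand explains why either chain lowers the number. The compounds shown leave open whether the ethyl ester matters: a carboxylic acid or an amide in its place, or a longer chain on the same oxygen, is not among them.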